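Removing a Methyl: Compound 4 Against McCoy Cell Growth

This account rests on a few compounds, and the source may have more. Where it says the series, first, only, none or still open, it means among the compounds named here.

Compound 1 `CC(C)(C)OC(=O)n1cnc(C[C@H]2N=C3C[C@H]4C[C@H](C4(C)C)[C@@]3(C)OC2=O)c1` gives, in an ADME assay on McCoy cells (Mus musculus) for antiproliferative activity, read by sulforhodamine B assay, with a stated time of 48 h (on this read-out higher numbers stand for weaker inhibition and lower numbers for stronger inhibition), only a limit of the assay, > 1300000 nM. Compound 2 `C[C@H]1N=C2C[C@H]3C[C@H](C3(C)C)[C@@]2(C)OC1=O` gives in this assay a limit too, > 1800000 nM. Compound 3 `C[C@@H]1N=C2C[C@@H]3C[C@@H](C3(C)C)[C@]2(C)OC1=O` likewise gives only a limit, > 2000000 nM.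

Compound 2 thus stands at a limit, not at a number (the limit of > 1800000 nM in this assay, at which 1 of the 3 values shown sits). Compound 4 `CC1(C)[C@H]2CC3=NCC(=O)O[C@]3(C)[C@@H]1C2` differs from it by hydrogen in place of methyl on a saturated ring carbon. For the measured compounds named here, the only measured step in this set, a step that the two limits leave unreadable from compound 2 to compound 3, is unreadable because the fact that compounds 2 and 3 differ only in the configuration as drawn joins two limits, so no size can be taken from it. Compound 4 is therefore expected to give another limit, and its step that the limit leaves unreadable from compound 2 to compound 4 is an estimate. Compound 4 is estimated at 2000000 nM, between 1000000 nM and 5000000 nM.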

Compound 4, half-maximal inhibitory concentration: > 2000000 nM
Compound 4: only a limit was reported; the forecaster's own chance of this, stated with the estimate: 85%; the middle value lies on the limit itself.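

In this assay compound 4 gives only a limit, > 2000000 nM; with compound 2 also at a limit, the step between them cannot be read. The compounds shown leave open what number, if any, this shared core would reach.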